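Notes on the acid-bearing side chain of the shared core

The source may report more compounds than this note shows. Statements on the series, on what has been measured and on what is new or still open speak of the compounds shown alone.

Measured so far in a functional assay on CHO cells for antagonist activity at sphingosine 1-phosphate receptor 2 (Homo sapiens), read by calcium flux; on this read-out lower numbers stand for stronger inhibition and higher numbers for weaker inhibition:
compound 1 `COC(C(=O)O)c1nn(Cc2cn3cc(OCC4CC4)c(Cl)cc3n2)c2ccccc2c1=O` gives 23 nM
compound 2 `O=C(O)Cc1nn(Cc2cn3cc(OCC4CC4)c(Cl)cc3n2)c2ccccc2c1=O` gives 20 nM
compound 3 `O=C(O)C1(c2nn(Cc3cn4cc(OCC5CC5)c(Cl)cc4n3)c3ccccc3c2=O)CC1` gives 16 nM

Compound 3 carries the lowest of the three numbers, but its separation from the others is small: a 1.3-fold lower number from compound 2 to compound 3 (0.10 log units; within the scatter) and a 1.4-fold lower number from compound 1 to compound 3 (0.16 log units; within the scatter), both within the scatter, so no order among the three can be claimed. The same holds for a 1.2-fold lower number from compound 1 to compound 2 (0.06 log units; within the scatter).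

Compound 4 `CC(C)(C(=O)O)c1nn(Cc2cn3cc(OCC4CC4)c(Cl)cc3n2)c2ccccc2c1=O` is the next member. Its change from compound 3 is 1-carboxy-1-methylethyl in place of 1-carboxycyclopropyl on an aromatic carbon.

Both steps into compound 3 altered this same substituent: from compound 1 the carboxy(methoxy)methyl became 1-carboxycyclopropyl, and from compound 2 the carboxymethyl did, with a 1.4-fold lower number from compound 1 to compound 3 (0.16 log units; within the scatter) and a 1.3-fold lower number from compound 2 to compound 3 (0.10 log units; within the scatter) as the outcome. Every variation of this substituent so far has stayed within the scatter in this assay. Going by the values given here, nothing in the three numbers suggests that exchanging the three-membered ring for the open 1-carboxy-1-methylethyl would behave differently, though no measured pair tests exactly this exchange. The expectation for compound 4 is therefore a step of about a 1.3-fold higher number from compound 3 to compound 4 (0.10 log units; within the scatter), that is, none beyond the scatter.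

Compound 4 is estimated at 20 nM in this assay, expected to fall between 8 nM and 50 nM.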

Compound 4, half-maximal inhibitory concentration in the sphingosine 1-phosphate receptor 2 assay: 7.7 nM
For compound 4 the middle estimate is 2.6-fold (0.41 log units) above the measured one; the measured number lies below the stated range.
By their numbers in the sphingosine 1-phosphate receptor 2 assay, from the lowest: compound 4; then compounds 3, 2 and 1 (each within the scatter of the next).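

In the sphingosine 1-phosphate receptor 2 assay this position, flat across the first three side chains, now shows a step beyond the scatter when the three-membered ring is opened (a 2.1-fold lower number from compound 3 to compound 4 (0.32 log units; beyond the scatter)). The 1-carboxy-1-methylethyl group of compound 4 also separates from the two side chains without a ring-free quaternary carbon (a 2.6-fold lower number from compound 2 to compound 4 (0.41 log units; beyond the scatter)) and (a 3.0-fold lower number from compound 1 to compound 4 (0.48 log units; beyond the scatter)), which makes compound 4 the strongest of the four in this assay, although 1-carboxy-1-methylethyl and 1-carboxycyclopropyl have the same heavy-atom count and differ in the ring alone. In a physicochemical assay for lipophilicity, at pH 7.4 (on this read-out higher numbers stand for higher lipophilicity and lower numbers for lower lipophilicity), compound 3 gives 2.46 and compound 4 gives 2.95. The same exchange goes with a higher measured lipophilicity, so the two changes run together in this one pair, without showing that one drives the other: the measured distribution coefficient of compound 3, 2.46, and of compound 4, 2.95, a number 0.49 log units higher (beyond the scatter)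

Going by these compounds, whether the lower number persists with larger groups on this carbon, such as two ethyl groups or a cyclobutane ring, or with a tetrazole or an amide in place of the carboxylic acid, stays open. One pair also does not separate the effect of lipophilicity on the sphingosine 1-phosphate receptor 2 assay from that of the ring opening itself.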